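The source may hold more compounds than are shown below. What is called first, only, known or untested is meant among the compounds shown, and "the series" means these compounds.

Measured so far:
Compound 1, `COc1cc(/C(Cl)=C/C=C(\C#N)C(=O)c2c[nH]c3ccccc23)cc(OC)c1OC`, gives 4000 nM.
Compound 2, `COc1ccc(/C(Cl)=C/C=C(\C#N)C(=O)c2c(C)[nH]c3ccccc23)cc1OC`, gives 29600 nM.

Both numbers come from a functional assay on MCF7 cells (Homo sapiens) for cytotoxicity, read by sulforhodamine B assay, with a stated time of 48 h; on this read-out lower numbers stand for stronger inhibition of growth and higher numbers for weaker inhibition of growth. Of the two, compound 2 has the higher number, meaning weaker inhibition of growth, and the gap between it and compound 1 lies beyond the usual scatter of the measurement. Within the data shown here, compound 1 and compound 2 differ from each other in two places at once, so no single step between them can be read off.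

Compound 3, `COc1cc(/C(Cl)=C/C=C(\C#N)C(=O)c2c(C)[nH]c3ccccc23)cc(OC)c1OC`, has not yet been measured. It is compound 2 with one change: methoxy in place of hydrogen on an aromatic carbon. After this change compound 3 carries the same arrangement of methoxy groups on its six-membered ring as compound 1, while keeping the methyl group on the shared core that compound 2 has. Among the measured compounds shown here, since compound 1, the only measured compound with that arrangement, gives 4000 nM, the step is expected to lower the number, by about a 3.7-fold lower number from compound 2 to compound 3 (0.57 log units; beyond the scatter). Compound 3 is therefore expected to give roughly 8000 nM in this assay, within a range from 2500 nM to 25000 nM.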

Compound 3, concentration for 50% growth inhibition: < 100 nM
Compound 3 gave a limit, no number (the forecaster's own chance of this, stated with the estimate: 5%); at least 80-fold (1.90 log units) between middle value and limit.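

In this assay, methoxy in place of hydrogen on the aromatic carbon brings an at least 290-fold lower number from compound 2 to compound 3 (2.47 log units; beyond the scatter), while methyl in place of hydrogen on the shared core brings an at least 40-fold lower number from compound 1 to compound 3 (1.60 log units; beyond the scatter). The first two compounds differed in two places at once and could not show this: with the methyl group present, one methoxy group on this carbon, ortho to a methoxy group, separates weak inhibition of growth from strong inhibition, and with the full set of methoxy groups present, the methyl group also has a large effect. Compound 3 gives a limit and not a number, so both steps give only the smallest possible size of each change: the limit of < 100 nM in this assay, at which 1 of the 3 values shown sits.

As far as these compounds go, how far the true value of compound 3 lies past that limit stays open, as does the size of the methoxy step on a core without the methyl group. Also open, from the compounds shown here alone, is whether an ethoxy group, a hydroxyl group, an amine or a chlorine atom on this same aromatic carbon would give a similar result.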